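The source may hold more compounds than are shown below. What is called first, only, known or untested is meant among the compounds shown, and "the series" means these compounds.

Measured so far:
- compound 1 `CC(C)(C)C[C@H](N)C(=O)Nc1cc2cc[nH]c(=O)c2cc1Cl`: 845 nM in an assay on isolated protein for inhibition of Rho-associated protein kinase 2 (Homo sapiens); on this read-out higher numbers stand for weaker inhibition and lower numbers for stronger inhibition
- compound 2 `N[C@H](C(=O)Nc1cc2cc[nH]c(=O)c2cc1Cl)C1CCCCC1`: 20 nM in this assay

Compound 2 stands lowest of the two numbers; its nearest neighbour, compound 1, gave a 42-fold lower number from compound 1 to compound 2 (1.63 log units; beyond the scatter) when its neopentyl was replaced by cyclohexyl on a saturated chain carbon bound to an amine nitrogen and a carbonyl carbon. Compound 3 `CC(C)[C@H](N)C(=O)Nc1cc2cc[nH]c(=O)c2cc1Cl` is not yet measured. It differs from compound 2 by isopropyl in place of cyclohexyl on a saturated chain carbon bound to an amine nitrogen and a carbonyl carbon. Going by the values given here, the only measured step at this position is the one from compound 1 to compound 2, and it was large, showing that the group on that carbon matters a great deal. Isopropyl is smaller than cyclohexyl and lacks its ring, so a weakening is expected, though with no closely matching step the size is uncertain. Compound 3 is therefore expected to give about 150 nM in this assay, within a range from 40 nM to 600 nM, a change of a 7.5-fold higher number from compound 2 to compound 3 (0.88 log units; beyond the scatter).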

Compound 3, half-maximal inhibitory concentration: 12 nM
The estimate for compound 3 lay 13-fold (1.10 log units) above the measured number, outside the stated range (below it).
By their numbers in this assay, from the lowest: compounds 3 and 2 (each within the scatter of the next); then compound 1.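

In this assay, replacing cyclohexyl with isopropyl gives a 1.7-fold lower number from compound 2 to compound 3 (0.22 log units; within the scatter) and so the two groups cannot be told apart here, although isopropyl has 3 heavy atoms against 6 and no ring. A six-membered ring is therefore not needed on this carbon for a low number, and among these three compounds neopentyl alone stands apart, as the change to isopropyl gives a 70-fold lower number from compound 1 to compound 3 (1.85 log units; beyond the scatter). Nothing available explains why neopentyl differs from the other two groups. Still open, from the compounds shown here alone, is whether a smaller methyl or an aromatic phenyl on this carbon would keep the number as low. Also open, going by these compounds, is whether tert-butyl on this carbon would behave like isopropyl and cyclohexyl or like neopentyl.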